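This account rests on a few compounds, and the source may have more. Where it says the series, first, only, none or still open, it means among the compounds named here.

Measured compounds:
Compound 1, `CN1CCC(NS(=O)(=O)c2ccccc2Nc2cc(-c3ccc4ccn(C)c4c3)c3nccnc3c2)C1`: in an assay on lysate for inhibition of 6-phosphofructo-2-kinase/fructose-2,6-bisphosphatase 3 (Homo sapiens), with stated times of 0.5 min and 45 min (a lower number here means a stronger inhibitor, a higher number a weaker inhibitor), compound 1 gives 3160 nM.
Compound 2, `Cn1ccc2ccc(-c3cc(Nc4ccccc4S(=O)(=O)NCC4CCOCC4)cc4nccnc34)cc21`: compound 2 returns only the assay limit, > 100000 nM.
Compound 3, `CC(=O)N1CCC(NC(=O)c2ccncc2Nc2cc(-c3ccc4ccn(C)c4c3)c3nccnc3c2)CC1`: compound 3 gives 31300 nM.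

Compound 3 has the higher of the two numbers; compound 1 sits clearly lower, while compound 2 is a limit only.

Compound 4, `CN1CC(NC(=O)c2ccncc2Nc2cc(-c3ccc4ccn(C)c4c3)c3nccnc3c2)C1`, differs from compound 3 by 1-methylazetidin-3-yl in place of 1-acetylpiperidin-4-yl on an amide-type nitrogen. Going by the values given here, the one measured step, an at least 31-fold higher number from compound 1 to compound 2 (1.50 log units; beyond the scatter), lies on a sulfonamide nitrogen, where the 1-methylpyrrolidin-3-yl of compound 1 carried the lower number; the entering 1-methylazetidin-3-yl resembles that group, so a move toward a lower number is expected, with the caveat that here the change sits on an amide nitrogen. Compound 4 is estimated at 6000 nM, range 1500 nM to 25000 nM, the expected step being a 5.2-fold lower number from compound 3 to compound 4 (0.72 log units; beyond the scatter).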

Compound 4, half-maximal inhibitory concentration: 9190 nM
Estimate against measurement, compound 4: 1.5-fold (0.19 log units) below, within the range that was stated.
By their numbers in this assay, from the lowest: compound 1; then compound 4; then compound 3. At a limit, above all of these: compound 2.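

Going by these compounds alone, on an amide-type nitrogen, the substituent also moves the number: a 3.4-fold lower number from compound 3 to compound 4 (0.53 log units; beyond the scatter), so sensitivity at this place is no longer seen only on a sulfonamide nitrogen. The change swaps a six-membered ring bearing acetyl for a four-membered ring bearing methyl, with 1-methylazetidin-3-yl being the smaller group by heavy atoms. Nothing measured here accounts for the step. Open, on these data alone, is whether the step follows ring size or the acetyl group. 1-Methylpiperidin-4-yl on the same amide-type nitrogen would separate the two.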